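Working notes: a methyl group on compound 2

The compounds below may be only part of what the source reports. "The series", "measured", "known", "first", "only" and "open" are said of these compounds alone.

In an ADME assay on HepG2 cells (Homo sapiens) for cytotoxicity, read by resazurin assay, with a stated time of 24 h (on this read-out higher numbers stand for lower toxicity in this test and lower numbers for higher toxicity in this test), compound 1 (`O=C(O)c1c(O)cccc1C=Cc1ccc2ccccc2c1`) gives 71000 nM and compound 3 (`CCN(CC)C(=O)c1c(CCc2ccc3ccccc3c2)cc(OC)cc1OC`) gives 59000 nM as two values within the scatter of each other. Compound 2 (`O=C(O)c1c(O)cccc1CCc1ccc2ccccc2c1`) reads > 100000 nM in this assay and this is a limit of the assay, not a number. Its standing in the series is therefore known only as a limit (the limit of > 100000 nM in this assay, at which 1 of the 3 values shown sits).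

Compound 4 (`Cc1cc(O)c(C(=O)O)c(CCc2ccc3ccccc3c2)c1`) has methyl in place of hydrogen on an aromatic carbon of compound 2, para to a carboxy group and meta to a hydroxy group (methyl in place of hydrogen on an aromatic carbon). For the measured compounds named here, no measured pair shows this change, so only a small move toward lower numbers is expected, perhaps none beyond the scatter. Going by the values given here, the expectation rests on compound 1 at 71000 nM and compound 3 at 59000 nM as the only true numbers. The expected at least 1.2-fold lower number from compound 2 to compound 4 (0.09 log units; that floor lies within the scatter) is modest, and another limit may be reported. For compound 4 the estimated value is 80000 nM with an expected range from 40000 nM to 130000 nM in this assay.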

Compound 4, half-maximal cytotoxic concentration: 38000 nM
For compound 4 the middle estimate is 2.1-fold (0.32 log units) above the measured one, and the stated range ends above it.
By their numbers in this assay, from the lowest: compounds 4, 3 and 1 (each within the scatter of the next). At a limit, above all of these: compound 2.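

Working from this assay, methyl in place of hydrogen on the aromatic carbon para to a carboxy group and meta to a hydroxy group gives an at least 2.6-fold lower number from compound 2 to compound 4 (0.42 log units; beyond the scatter) and is the first step in the series that can be read at all. It shows that this position is sensitive to substitution, since this single added methyl moves the read-out toward higher toxicity in this test, by more than the scatter. Compound 2 reads > 100000 nM, which is a limit of the assay and not a number, so only a floor for the step is known: the limit of > 100000 nM in this assay, at which 1 of the 4 values shown sits.

From the compounds shown here alone, the full size of the step stays open. Also open, going by these compounds, is whether an amine or a longer chain on this carbon would move the number in the same direction.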